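This account rests on a few compounds, and the source may have more. Where it says the series, first, only, none or still open, it means among the compounds named here.

Compound 1 `ClCc1cccc(Cn2cnc3c(Cl)ncnc32)c1` and compound 2 `ClCc1cccc(Cn2cnc3c(Cl)nc(Cl)nc32)c1` share one core, while compound 3 `ClCc1ccccc1Cn1cnc2ncnc(Cl)c21` carries the same atoms joined differently; the difference between the two cores is not broken down here. In a functional assay on U-251 cells (Homo sapiens) for cytotoxicity, read by sulforhodamine B assay, with a stated time of 48 h (a lower number here means a stronger inhibitor of growth, a higher number a weaker inhibitor of growth), compound 1 gives 1820 nM, and compound 2 gives 1690 nM. The change from compound 1 to compound 2 is chloro in place of hydrogen on an aromatic carbon and it made a 1.1-fold lower number from compound 1 to compound 2 (0.03 log units; within the scatter). Compound 3 gives 1900 nM in this assay, so the three measured compounds sit close together, and no order among them is claimed.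

Compound 4 `ClCc1ccccc1Cn1cnc2nc(Cl)nc(Cl)c21` has not yet been measured. Its change from compound 3 is chloro in place of hydrogen on an aromatic carbon, the same change as that from compound 1 to compound 2, at a place described in the same words. Because the earlier change made a 1.1-fold lower number from compound 1 to compound 2 (0.03 log units; within the scatter), the step from compound 3 to compound 4 in this assay is expected to be about as small, a 1.1-fold lower number from compound 3 to compound 4 (0.04 log units; within the scatter). Compound 4 is therefore expected to give about 1750 nM, with a likely range from 900 nM to 3400 nM.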

Compound 4, concentration for 50% growth inhibition: 330 nM
Compound 4: middle estimate off by 5.3-fold (0.72 log units), on the high side, outside the stated range (below it).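

In this assay, chloro in place of hydrogen on an aromatic carbon gave a 5.8-fold lower number from compound 3 to compound 4 (0.76 log units; beyond the scatter), so the size of the step did not carry over from one core to the other: the same change on two cores in this assay, a 1.1-fold lower number (0.03 log units; within the scatter) from compound 1 to compound 2 and a 5.8-fold lower number (0.76 log units; beyond the scatter) from compound 3 to compound 4, 5.3-fold (0.73 log units) apart, beyond the scatter of two such steps In this series, then, the step measured on the core of compound 1 gives no safe measure of the same change on the core of compound 3, and the change has to be read on each core separately. These two pairs do not show which part of the difference between the cores goes with the gap, nor how a further core would behave, and they say nothing of the reason for it.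

The compounds shown carry only hydrogen or chloro at this place between two ring nitrogen atoms, so it remains open whether an amine or a methoxy group there would follow the larger step or the smaller one. As far as these compounds go, it also remains open whether the larger step would persist on the core of compound 3 with a hydroxymethyl group in place of the chloromethyl group.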